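The source may hold more compounds than are shown below. What is called first, only, known or untested is meant among the compounds shown, and "the series" means these compounds.

Measured compounds:
compound 1, `CN(C)CCNc1nc(-c2ccc(NC(=O)Nc3ccc(F)cc3)cc2)nc2ccsc12`: 540 nM
compound 2, `Cc1ccc(NC(=O)Nc2ccc(-c3nc(NCCCN(C)C)c4sc(Cl)c(Cl)c4n3)cc2)cc1`: 4980 nM

Both numbers come from a functional assay on MDA-MB-231 cells (Homo sapiens) for cytotoxicity, read by MTT assay, with a stated time of 72 h; a lower number here means a stronger inhibitor, a higher number a weaker inhibitor. Compound 1 gives 540 nM, the lower of the two values, and compound 2 gives 4980 nM; the gap between them is beyond the scatter, so compound 1 is the stronger inhibitor of the pair. These two differ in several places at once, so nothing about any single change can be read from that gap. Compound 3, `CN(C)CCNc1nc(-c2ccc(NC(=O)Nc3ccc(Cl)cc3)cc2)nc2ccsc12`, is not yet measured. It keeps the shared core of compound 1 and alters one thing: chloro in place of fluoro on an aromatic carbon. Among the measured compounds shown here, no measured pair shows this swap on its own, so no direct guide exists. The swap exchanges one heavy atom for one heavy atom, so a small step from compound 1 to compound 3 is expected, in either direction and most likely within the scatter. Compound 3 is expected to give about 450 nM in this assay, within a range from 180 nM to 1200 nM. That estimate means a step of a 1.2-fold lower number from compound 1 to compound 3 (0.08 log units; within the scatter).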

Compound 3, half-maximal inhibitory concentration: 310 nM
Compound 3: middle estimate off by 1.5-fold (0.16 log units), on the high side; the measured number falls inside the stated range.
By their numbers in this assay, from the lowest: compounds 3 and 1 (each within the scatter of the next); then compound 2.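

In this assay, putting chloro in place of fluoro on this aromatic carbon, para to a large group, gives a 1.7-fold lower number from compound 1 to compound 3 (0.24 log units; within the scatter), so compound 1 and compound 3 cannot be told apart in this test. Among the compounds shown here, this is the first comparison here that isolates a single change, which the gap between compound 1 and compound 2 could not do because those two differ in several places. Nothing available explains this result or links it to any property of either halogen.

The compounds shown leave open how a methoxy or a trifluoromethyl group would fare at this same place. They also leave open whether the swap would give a similar result on the core of compound 2.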